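Aryl swap at the aminopyrimidine: 4-methoxy to 3,5-dimethoxy

This account rests on a few compounds, and the source may have more. Where it says the series, first, only, none or still open, it means among the compounds named here.

Measured so far:
compound 1 `Clc1ccc(Nc2ccnc(NCCCCNc3ccnc4cc(Cl)ccc34)n2)cc1`, an ADME assay on Vero cells (Chlorocebus sabaeus) for cytotoxicity, read by neutral red uptake, with a stated time of 72 h (a lower number here means a stronger inhibitor, a higher number a weaker inhibitor), 11000 nM
compound 2 `COc1ccc(Nc2ccnc(NCCCCNc3ccnc4cc(Cl)ccc34)n2)cc1`, this assay 11100 nM

Compound 2 and compound 1 give numbers that sit within the scatter of each other, as the step of a 1.0-fold higher number from compound 1 to compound 2 (0.00 log units; within the scatter) shows. Compound 3 `COc1cc(Nc2ccnc(NCCCCNc3ccnc4cc(Cl)ccc34)n2)cc(OC)c1` carries 3,5-dimethoxyphenyl in place of 4-methoxyphenyl on a nitrogen on an aromatic ring. Within the data shown here, the only measured step, a 1.0-fold higher number from compound 1 to compound 2 (0.00 log units; within the scatter), exchanged one group on this same phenyl ring without moving the number, so a further change on that ring is expected to leave the reading close to compound 2; the estimated step is a 1.1-fold higher number from compound 2 to compound 3 (0.03 log units; within the scatter). Compound 3 is therefore expected to give about 12000 nM, with a range from 5000 nM to 28000 nM.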

Compound 3, half-maximal inhibitory concentration: 12500 nM
Beside the measured number, compound 3's estimate is 1.0-fold (0.02 log units) below it; the range from low to high includes it.
By their numbers in this assay, from the lowest: compounds 1, 2 and 3 (each within the scatter of the next).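

In this assay, the 3,5-dimethoxyphenyl group reads like the 4-methoxyphenyl group (a 1.1-fold higher number from compound 2 to compound 3 (0.05 log units; within the scatter)) and like the 4-chlorophenyl group (a 1.1-fold higher number from compound 1 to compound 3 (0.06 log units; within the scatter)). Among these compounds, the earlier pair showed only one group exchanged for another on this ring; here the substituent on the nitrogen grows from 8 to 10 heavy atoms and gains a second hydrogen-bond acceptor, with the reading still within the scatter. Nothing at hand accounts for this flat reading.

Open, going by these compounds, is whether an amine or a carboxylic acid on this phenyl ring would also stay within the scatter.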